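Compound 2 to compound 4: an expected solubility step

This account rests on a few compounds, and the source may have more. Where it says the series, first, only, none or still open, it means among the compounds named here.

Of the compounds shown here, three have been read in a physicochemical assay for solubility, read by LC-MS, in phosphate buffer, with a stated time of 24 h, at pH 7.4 (on this read-out lower numbers stand for lower solubility and higher numbers for higher solubility), so far. Compound 1 (`Cc1nc(CN(C)C)ccc1-c1cnc(NCc2c(F)ccc3c2CCO3)c2cn[nH]c(=O)c12`) gives > 1000000 nM as a limit of the assay. Compound 2 (`CN(c1ccccc1)c1cnc(NCc2c(F)ccc3c2CCO3)n2cnnc12`) gives < 2000 nM as a limit. Compound 3 (`Cc1ncccc1-c1cnc(NCc2c(F)ccc3c2CCO3)n2c(=O)[nH]nc12`) gives < 2000 nM as a limit too. Compound 2 therefore stands at the low limit shared with compound 3, with no true number of its own. Compound 4 (`O=C1CC2(CC2)CN1c1cnc(NCc2c(F)ccc3c2CCO3)n2cnnc12`) departs from compound 2 through (a group of 8 heavy atoms (6 carbon, 1 nitrogen, 1 oxygen; one three-membered non-aromatic ring of carbon only, one five-membered non-aromatic ring with 1 hetero atom) in place of a group of 8 heavy atoms (7 carbon, 1 nitrogen; one six-membered aromatic ring of carbon only), on an aromatic carbon). No measured step sizes this change. A moderate upward move in this assay is expected, estimated as an at least 5.0-fold higher number from compound 2 to compound 4 (0.69 log units; beyond the scatter) for now. Compound 4 is estimated at 10000 nM (expected range 2000 nM to 100000 nM).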

Compound 4, solubility: 130000 nM
For compound 4 the middle estimate is 13-fold (1.11 log units) below the measured one, outside the stated range (above it).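

In this assay, the group with one three-membered and one five-membered non-aromatic ring in place of methyl(phenyl)amino gives an at least 65-fold higher number from compound 2 to compound 4 (1.81 log units; beyond the scatter), the first step read at this aromatic carbon. Compound 4 carries a true number, while the size of the step stays open-ended, as compound 2 stands at a limit: the limit of < 2000 nM in this assay, at which 2 of the 4 values shown sit.

On these data alone, whether the step follows the loss of the six-membered aromatic ring or the entry of the carbonyl stays open. As far as these compounds go, how a morpholine or a carboxylic acid on this aromatic carbon would read also stays open.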